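A few compounds are considered here, and "the series" means these few. Any claim that something is new, unique, unknown or untested is made for them only; others in the source may bear on it.

Three compounds share one core. Compound 1 `CCc1ccccc1-n1nc(C)c2c1NC(=O)[C@H](C)S[C@@H]2c1ccc(Oc2ccccc2)cc1` gives 1100 nM in an assay on isolated protein for agonist activity at Bile acid receptor (Homo sapiens), read by AlphaScreen, with a stated time of 30 min; a lower number here means that less compound is needed, a higher number that more compound is needed for the effect. Compound 2 `COc1cccc(-c2ccc([C@H]3S[C@@H](C)C(=O)Nc4c3c(C)nn4-c3ccccc3C)cc2)c1` gives 1800 nM in this assay, and compound 3 `Cc1nn(-c2ccccc2Br)c2c1C(c1ccc(Oc3ccccc3)cc1)SC(C)C(=O)N2` gives 1800 nM in this assay. Compound 2 stands level with compound 3 at the digits shown, the two together at the highest numbers of the three, and its gap to compound 1 lies within the usual scatter, so no order among the three can be read from these numbers.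

Compound 4 `Cc1ccccc1-n1nc(C)c2c1NC(=O)[C@H](C)S[C@@H]2c1ccc(Oc2ccc(C(=O)O)cc2)cc1` differs from compound 2 in one place: 4-carboxyphenoxy in place of 3-methoxyphenyl on an aromatic carbon. For the measured compounds named here, no measured pair shows such a change, so the step is expected to be modest, in no settled direction, and the estimate for compound 4 in this assay is 1200 nM, with a range from 400 nM to 4000 nM, which means a step of a 1.5-fold lower number from compound 2 to compound 4 (0.18 log units; within the scatter) that is expected to stay near the scatter.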

Compound 4, half-maximal effective concentration: "not active" (no number reported)
Compound 4: no number reported; there is nothing to compare the estimate with.
By their numbers in this assay, from the lowest: compounds 1, 2 and 3 (each within the scatter of the next).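

For the compounds shown here, for compound 4, reported in this assay as "not active" without a number, no step from compound 2 can be read. No available evidence bears on this result. Whether the 4-carboxyphenoxy group alone accounts for that report remains open.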